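The source may report more compounds than this note shows. Statements on the series, on what has been measured and on what is new or still open speak of the compounds shown alone.

Measured compounds in an assay on SK-OV-3 cells for inhibition of Indoleamine 2,3-dioxygenase 1 (Homo sapiens); on this read-out lower numbers stand for stronger inhibition and higher numbers for weaker inhibition:
compound 1, `O=C(Nc1ccc(Cl)cc1)C(=O)N1CCC(c2ccnc3ccc(F)cc23)CC1`: 15 nM
compound 2, `O=C(Nc1ccc(C(F)(F)F)cc1)C(=O)N1CCC(c2ccnc3ccc(F)cc23)CC1`: 90 nM
compound 3, `N#Cc1ccc2nccc(C3CCN(C(=O)C(=O)Nc4ccc(Cl)cc4)CC3)c2c1`: 118 nM

Compound 1 gives the lowest of these three numbers. Among the compounds with values here, the step of a 6.0-fold higher number from compound 1 to compound 2 (0.78 log units; beyond the scatter) and the step of a 7.9-fold higher number from compound 1 to compound 3 (0.90 log units; beyond the scatter) both raise the number beyond the scatter, and both alter a substituent on an aromatic ring of the shared core; compound 2 and compound 3 are the only comparisons available.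

Compound 4, `O=C(Nc1ccc(Cl)cc1)C(=O)N1CC[C@@H](c2ccnc3ccc(F)cc23)[C@@H](O)C1`, is not yet measured. It differs from compound 1 by hydroxy in place of hydrogen on a saturated ring carbon. Neither measured step touches this saturated ring, and none of them bears directly on the change. Within the data shown here, they show only that the two single changes tried elsewhere on compound 1 each gave a modest rise in this assay. Among the measured compounds shown here, with no step at this position in hand, the working expectation for this assay is a change of small to modest size, a rise somewhat more likely than a fall, and a result within the scatter of compound 1 remains well possible. Compound 4 is estimated at 28 nM, with a range of 8 nM to 100 nM, which corresponds to the expected step of a 1.9-fold higher number from compound 1 to compound 4 (0.27 log units; within the scatter).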

Compound 4, half-maximal inhibitory concentration: 3000 nM
Compound 4: middle estimate off by 110-fold (2.03 log units), on the low side; measured number above the stated range.
By their numbers in this assay, from the lowest: compound 1; then compounds 2 and 3 (each within the scatter of the next); then compound 4.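

In this assay, hydroxy in place of hydrogen on a saturated ring carbon gives a 200-fold higher number from compound 1 to compound 4 (2.30 log units; beyond the scatter), a large step, whereas the earlier changes on aromatic carbons gave only modest ones: a 6.0-fold higher number from compound 1 to compound 2 (0.78 log units; beyond the scatter) and a 7.9-fold higher number from compound 1 to compound 3 (0.90 log units; beyond the scatter). The saturated ring therefore proves far more sensitive to this single change than either aromatic substituent change suggested, at least at this carbon, which lies next to the ring atom that bears a large group and two ring bonds from the ring nitrogen. Nothing at hand accounts for the size of this step.

The compounds shown leave open whether the step is specific to hydroxy or extends to other groups on this carbon, such as methyl, fluoro or methoxy. They also leave open whether hydroxy with the opposite stereochemistry at this carbon, or hydroxy on another carbon of the same ring, would give a step of similar size.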